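A few compounds are considered here, and "the series" means these few. Any claim that something is new, unique, unknown or untested is made for them only; others in the source may bear on it.

Compound 1 `Brc1cccc2ccn(CCN3CCN4CCCCC4C3)c12` gives 13% in an assay on HEK293 cells for binding affinity to 5-hydroxytryptamine receptor 7 (Homo sapiens), read by radioligand binding, tested at 1 uM; a lower number here means less inhibition, a higher number more inhibition at the concentration tested (going by the name of the read-out).
Compound 2 `CN1CCCN(CCn2ccc3ccc(O)cc32)CC1` gives 28% in this assay.
Compound 3 `CN1CCCN(CCn2ccc3ccc(C(F)(F)F)cc32)CC1` gives 89% in this assay.

Compound 3 stands highest of the three measured compounds, beyond the scatter from both of the others. Compound 4 `CCc1ccc2ccn(CCN3CCCN(C)CC3)c2c1` differs from compound 3 in one place: ethyl in place of trifluoromethyl on an aromatic carbon. Among the compounds with values here, the only measured step touching that position is a number 61 percentage points higher from compound 2 to compound 3 (beyond the scatter), the step in which trifluoromethyl arrived; no measured step removes it again or installs ethyl, so that step bears on the present change only indirectly. Taking trifluoromethyl away is therefore expected to give back part of what it brought, while ethyl is expected to keep more than hydroxy did, a number 24 percentage points lower from compound 3 to compound 4 (beyond the scatter). Compound 4 is estimated at 65%, with a range from 35% to 90%.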

Compound 4, a percentage reported as inhibition, at one concentration (the size of the read-out at that concentration, not a potency): 66%
The estimate for compound 4 lay 1 percentage points below the measured number, and the stated range covers the measured number.
By their numbers in this assay, from the lowest: compound 1; then compound 2; then compound 4; then compound 3.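

Within the data shown here, at this position on the shared core, trifluoromethyl is not the only group that gives a high number in this assay: ethyl, which has no fluorine, also stands well above hydroxy (a number 38 percentage points higher from compound 2 to compound 4 (beyond the scatter)). Ethyl still does not match trifluoromethyl (a number 23 percentage points lower from compound 3 to compound 4 (beyond the scatter)), so the three groups fall in a clear order here, with hydroxy lowest and trifluoromethyl highest. Nothing measured here explains why these groups differ.

Still open, from the compounds shown here alone, is where a methoxy group, a chlorine atom or an amine at this place would fall in that order. Going by these compounds, it is equally open whether a longer chain, such as propyl, would raise or lower the number.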